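Methylamino to amino: compound 2 to compound 3

A few compounds are considered here, and "the series" means these few. Any claim that something is new, unique, unknown or untested is made for them only; others in the source may bear on it.

Measured in a functional assay on HCT-116 cells (Homo sapiens) for antiproliferative activity, read by MTT assay, with a stated time of 48 h; a lower number here means a stronger inhibitor, a higher number a weaker inhibitor:
- compound 1 (`CCCCCC(CCO)n1cnc2c(N)ncnc21`) gives > 50000 nM (a limit)
- compound 2 (`CCCCCCC(CCO)n1cnc2c(NC)ncnc21`) gives > 50000 nM (a limit)

In this assay compound 2 stands at > 50000 nM, which is a limit of the assay and not a number. Neither measured compound has a number (the limit of > 50000 nM in this assay, at which 2 of the 2 values shown sit).

Compound 3 (`CCCCCCC(CCO)n1cnc2c(N)ncnc21`) differs from compound 2 by one change (hydrogen in place of methyl on a nitrogen on an aromatic ring): hydrogen in place of methyl on a nitrogen on an aromatic ring, so methylamino becomes amino. Among the measured compounds shown here, no measured pair shows this change. Compound 1 also bears the amino group, and its value of > 50000 nM is a limit too. The expected step of a number no higher from compound 2 to compound 3 (the limit leaves the size open) in this assay is none beyond the scatter, in either direction. Compound 3 is estimated at 50000 nM, with an expected range of 20000 nM to 100000 nM, and a reading that is again only a limit is the likeliest outcome.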

Compound 3, half-maximal inhibitory concentration: > 50000 nM
Compound 3 was reported as a limit (the forecaster's own chance of this, stated with the estimate: 75%); the middle value lies on the limit itself.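

Neither the step between compound 2 and compound 3 nor that between compound 1 and compound 3 can be read in this assay, as each value is a limit and not a number: the limit of > 50000 nM in this assay, at which 3 of the 3 values shown sit.

The compounds shown leave open whether either change, methylamino to amino or methyl in place of hydrogen on the saturated chain, has any effect on antiproliferative activity.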